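This account rests on a few compounds, and the source may have more. Where it says the series, first, only, none or still open, it means among the compounds named here.

In a functional assay on the whole organism (T-cell) with Rattus norvegicus as the target, with a stated time of 4 days (on this read-out higher numbers stand for an effect only at larger amounts of compound and lower numbers for an effect already at smaller amounts), the measured compounds stand as follows.
Compound 1 `CCCCCCCOc1ccc(CCC(N)(CO)CCCC)cc1` gives > 10 mg/kg, a limit of the assay.
Compound 2 `CCCCCCCOc1ccc(CC[C@@](N)(CO)CCC)cc1` gives 4.4 mg/kg.
Compound 3 `CCCCCCCOc1ccc(CC[C@](N)(CO)CCC)cc1` gives > 10 mg/kg, also a limit of the assay.

Compound 3 therefore stands at the limit, as does compound 1 (the limit of > 10 mg/kg in this assay, at which 2 of the 3 values shown sit); only compound 2 gives a number, and the step of an at least 2.2-fold higher number from compound 2 to compound 3 (0.35 log units; beyond the scatter) rests on (the fact that compounds 2 and 3 differ only in the configuration as drawn). Compound 4 `CCCCCCCOc1ccc(CCC(N)(CC)CO)cc1` differs from compound 3 by a group of 6 heavy atoms (4 carbon, 1 nitrogen, 1 oxygen; no ring) in place of a group of 7 heavy atoms (5 carbon, 1 nitrogen, 1 oxygen; no ring), on a saturated chain carbon, two bonds along the chain from an aromatic carbon. The measured steps of the same kind remove one chain carbon: an at least 2.2-fold lower number from compound 1 to compound 2 (0.35 log units; beyond the scatter), while a step that the two limits leave unreadable from compound 1 to compound 3. Compound 3 is only a limit, so the step of an at least 1.6-fold lower number from compound 3 to compound 4 (0.22 log units; that floor lies within the scatter) that is expected cannot be read in direction with any confidence. Compound 4 is estimated at 6 mg/kg, between 2 mg/kg and 15 mg/kg.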

Compound 4, dose for 50% inhibition: 0.044 mg/kg
Estimate against measurement, compound 4: 140-fold (2.13 log units) above, and the stated range ends above it.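

In this assay, the group with one chain carbon fewer than the 1-amino-1-(hydroxymethyl)butyl group gives a 100-fold lower number from compound 2 to compound 4 (2.00 log units; beyond the scatter) and an at least 220-fold lower number from compound 3 to compound 4 (2.35 log units; beyond the scatter), while hydrogen in place of ethyl gives an at least 220-fold lower number from compound 1 to compound 4 (2.35 log units; beyond the scatter). Among the compounds shown here, no earlier step at this position could be read at this size, so the length of this chain matters far more than the earlier compounds showed. Two of these steps start from a limit: the limit of > 10 mg/kg in this assay, at which 2 of the 4 values shown sit.

From the compounds shown here alone, compound 4 is drawn with no defined stereocentre, so it remains open whether configuration matters here as it does between compound 2 and compound 3. Going by these compounds, whether a methyl group in place of the ethyl would go further also remains open.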